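Adding a second chloro to a purine core on cancer cells

A few compounds are considered here, and "the series" means these few. Any claim that something is new, unique, unknown or untested is made for them only; others in the source may bear on it.

Measured so far:
- Compound 1, `ClCc1ccc(Cn2cnc3nc(Cl)nc(Cl)c32)cc1`: 8310 nM
- Compound 2, `ClCc1ccccc1Cn1cnc2ncnc(Cl)c21`: 58900 nM

In a functional assay on OVCAR-8 cells (Homo sapiens) for cytotoxicity, read by sulforhodamine B assay, with a stated time of 48 h (a higher number here means that more compound is tolerated, a lower number that less compound is tolerated), compound 1 gives 8310 nM and compound 2 gives 58900 nM. Compound 2 stands at the highest of the two numbers, meaning more of it is tolerated; the gap down to compound 1 lies beyond the scatter. These two compounds differ in more than one place, so their gap cannot be tied to a single change.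

Compound 3, `ClCc1ccccc1Cn1cnc2nc(Cl)nc(Cl)c21`, is the unmeasured one. It keeps the benzyl side of compound 2 and differs from it in one place: chloro in place of hydrogen on an aromatic carbon. The new chloro sits between two ring nitrogen atoms of the fused core, meta to the chloro group already present. The resulting compound carries the same two chloro groups on the core as compound 1.

Going by the values given here, for this step the expectation is a lowering of the number, of moderate size, since compound 1, the only compound with two chloro groups on the core, gives 8310 nM in this assay. The expected step is a 2.9-fold lower number from compound 2 to compound 3 (0.47 log units; beyond the scatter). Compound 3 is therefore estimated at 20000 nM, with a range from 5000 nM to 60000 nM.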

Compound 3, concentration lethal to 50% of the cells: 75900 nM
For compound 3 the middle estimate is 3.8-fold (0.58 log units) below the measured one, outside the stated range (above it).
By their numbers in this assay, from the lowest: compound 1; then compounds 2 and 3 (each within the scatter of the next).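

In this assay, placing chloro on this aromatic carbon between two ring nitrogen atoms gives a 1.3-fold higher number from compound 2 to compound 3 (0.11 log units; within the scatter). On the benzyl side shared by compound 2 and compound 3, this change therefore does not separate the two compounds, so a second chloro on the core is not enough on its own to produce a number like that of compound 1. Nothing available explains why this swap leaves the two compounds indistinguishable here.

Only hydrogen and chloro are shown at this position, so it remains open whether an amine or a methoxy group there would shift the number. Going by these compounds, it is also open whether the same swap would stay within the scatter on the benzyl side of compound 1.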